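A few compounds are considered here, and "the series" means these few. Any claim that something is new, unique, unknown or untested is made for them only; others in the source may bear on it.

Compound 2 `CN1CCN(c2ccc(Nc3ncc4nc(Nc5ccc(F)cc5)n([C@@H]5CCN(S(=O)(=O)C6CC6)C5)c4n3)cc2)CC1` gives 2.5 nM in a functional assay on HCC827 cells (Homo sapiens) for antiproliferative activity, read by MTT assay, with a stated time of 72 h (on this read-out lower numbers stand for stronger inhibition and higher numbers for weaker inhibition), the higher of the two numbers in hand; compound 1 `CN1CCN(c2ccc(Nc3ncc4nc(Nc5ccc(F)cc5)n([C@H]5CCCN(C(=O)CO)C5)c4n3)cc2)CC1` gives 1.8 nM, and the change a 1.4-fold higher number from compound 1 to compound 2 (0.14 log units; within the scatter) shows these two within the scatter. Compound 3 `CN1CCN(c2ccc(Nc3ncc4nc(Nc5ccc(F)cc5)n([C@@H]5CCN(C(=O)OC(C)(C)C)C5)c4n3)cc2)CC1` carries tert-butoxycarbonyl in place of cyclopropylsulfonyl on an amine nitrogen in a ring. Within the data shown here, the only measured step on this ring nitrogen is a 1.4-fold higher number from compound 1 to compound 2 (0.14 log units; within the scatter), a swap of both ring and substituent without effect beyond the scatter, so for compound 3 the expected step of a 1.2-fold higher number from compound 2 to compound 3 (0.08 log units; within the scatter) is none beyond the scatter. Compound 3 is accordingly estimated at 3 nM, within 1 nM to 10 nM.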

Compound 3, half-maximal inhibitory concentration: 27 nM
The estimate for compound 3 lay 9.0-fold (0.95 log units) below the measured number; the whole stated range lies below it.
By their numbers in this assay, from the lowest: compounds 1 and 2 (each within the scatter of the next); then compound 3.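

On an amine nitrogen in a ring, the group carried now matters in this assay: tert-butoxycarbonyl in place of cyclopropylsulfonyl gives an 11-fold higher number from compound 2 to compound 3 (1.03 log units; beyond the scatter), whereas the earlier step at this site stayed within the scatter. The 1-(tert-butoxycarbonyl)pyrrolidin-3-yl group also separates from 1-((hydroxymethyl)carbonyl)piperidin-3-yl, with a 15-fold higher number from compound 1 to compound 3 (1.18 log units; beyond the scatter), so this site does not accept every group equally. Nothing available here accounts for this loss. Still open, as far as these compounds go, is how a free ring amine, an acetyl group or a methylsulfonyl group on the same nitrogen would compare, and which part of tert-butoxycarbonyl carries the change.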